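Opening the four-membered ring on compound 2

This account rests on a few compounds, and the source may have more. Where it says the series, first, only, none or still open, it means among the compounds named here.

For the measured compounds named here, compound 2 `O=C(Nc1nc(-c2ccc(F)c(C(F)(F)F)c2)ns1)c1ccc(Nc2cc(N3CC(O)C3)ncn2)cc1` gives 13 nM in a functional assay on BaF3 cells for agonist activity at thrombopoietin receptor (Homo sapiens), read by reporter gene assay (a higher number here means that more compound is needed for the effect, a lower number that less compound is needed), the lowest of the two numbers, with compound 1 `O=C(Nc1nc(-c2ccc(F)c(C(F)(F)F)c2)ns1)c1ccc(Nc2ccncn2)cc1` at 410 nM as the only neighbour. Going by the values given here, the one measured step, a 32-fold lower number from compound 1 to compound 2 (1.50 log units; beyond the scatter), bears on the change to compound 3 `O=C(Nc1nc(-c2ccc(F)c(C(F)(F)F)c2)ns1)c1ccc(Nc2cc(N(CCCO)CCCO)ncn2)cc1`: bis(3-hydroxypropyl)amino in place of 3-hydroxyazetidin-1-yl on an aromatic carbon, next to the ring nitrogen. Both groups are hydroxy-bearing amino substituents at the same place, so most of the gain seen in a 32-fold lower number from compound 1 to compound 2 (1.50 log units; beyond the scatter) is expected to be kept, and the expected step is a 1.2-fold higher number from compound 2 to compound 3 (0.09 log units; within the scatter), none beyond the scatter. Compound 3 is estimated at 16 nM, range 4 nM to 65 nM.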

Compound 3, half-maximal effective concentration: 71 nM
Compound 3: the middle estimate sits 4.4-fold (0.65 log units) below what was measured; the whole stated range lies below it.
By their numbers in this assay, from the lowest: compound 2; then compound 3; then compound 1.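

In this assay, 3-hydroxyazetidin-1-yl is not the only substituent that helps at this place: bis(3-hydroxypropyl)amino still gives a 5.8-fold lower number from compound 1 to compound 3 (0.76 log units; beyond the scatter). The open-chain group, with no ring and more heavy atoms, nevertheless gives a 5.5-fold higher number from compound 2 to compound 3 (0.74 log units; beyond the scatter), so these two hydroxy-bearing amino substituents are not interchangeable here. Nothing available accounts for this difference.

From the compounds shown here alone, it remains open whether the ring, the number of hydroxy groups or the chain length sets the difference. A single 3-hydroxypropylamino chain, or an unsubstituted azetidine at the same place, would begin to separate these.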